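A Bromine Change in a Narrow Cytotoxicity Series

This account rests on a few compounds, and the source may have more. Where it says the series, first, only, none or still open, it means among the compounds named here.

In a functional assay on B16 cells (Mus musculus) for cytotoxicity, read by CCK-8 assay, with a stated time of 24 h (on this read-out higher numbers stand for weaker inhibition and lower numbers for stronger inhibition), compound 1 `COc1ccccc1Oc1c(N)nc(-c2ccccc2)nc1OCCO` gives 31100 nM, compound 2 `COc1ccccc1Oc1c(N)nc(Cc2ccccc2)nc1OCCO` gives 47400 nM and compound 3 `COc1ccccc1Oc1c(N)nc(-c2ccc(F)cc2)nc1OCCO` gives 30100 nM. Compound 3 therefore cannot be separated from either of the other two, as the measured steps show: a 1.0-fold lower number from compound 1 to compound 3 (0.01 log units; within the scatter) and a 1.6-fold lower number from compound 2 to compound 3 (0.20 log units; within the scatter).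

Compound 4 `COc1ccccc1Oc1c(N)nc(-c2cccc(Br)c2)nc1OCCO` has 3-bromophenyl in place of 4-fluorophenyl, on the aromatic carbon between two ring nitrogen atoms: 3-bromophenyl in place of 4-fluorophenyl on an aromatic carbon. All three measured steps concern this same place. Fluoro in place of hydrogen gave a 1.0-fold lower number from compound 1 to compound 3 (0.01 log units; within the scatter), and benzyl in place of phenyl gave a 1.5-fold higher number from compound 1 to compound 2 (0.18 log units; within the scatter). Even the change from benzyl to 4-fluorophenyl gave only a 1.6-fold lower number from compound 2 to compound 3 (0.20 log units; within the scatter). Among the compounds with values here, none of these steps leaves the scatter, so the series so far shows little response to changes at this place. Within the data shown here, the data hold no bromo compound and no other group in the 3-position of the phenyl ring, so this expectation is an extrapolation and its range stays wide.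

No step beyond the scatter is expected, and the estimated change is a 1.0-fold lower number from compound 3 to compound 4 (0.02 log units; within the scatter). For compound 4 the estimated value is 29000 nM, with an expected range from 15000 nM to 58000 nM.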

Compound 4, half-maximal inhibitory concentration: 21900 nM
For compound 4 the middle estimate is 1.3-fold (0.12 log units) above the measured one; the range from low to high includes it.
By their numbers in this assay, from the lowest: compounds 4, 3, 1 and 2 (each within the scatter of the next, the first and the last beyond it).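

In this assay, within the data shown here, the change to 3-bromophenyl yields the only step at this place that leaves the scatter, a 2.2-fold lower number from compound 2 to compound 4 (0.34 log units; beyond the scatter), and it is a modest one, measured against the benzyl group of compound 2. Against the groups without that benzyl carbon the series stays flat, with a 1.4-fold lower number from compound 3 to compound 4 (0.14 log units; within the scatter) and a 1.4-fold lower number from compound 1 to compound 4 (0.15 log units; within the scatter), both within the scatter, so compound 4 cannot be separated from compound 1 or compound 3, and a bromine on the phenyl ring fits the same narrow band of values. Nothing at hand explains these steps.

The step from compound 3 to compound 4 moves the halogen and exchanges it at once, so the compounds shown leave open whether bromine itself or its place on the phenyl ring matters, which 4-bromophenyl or 3-fluorophenyl could separate. They also leave open whether this place responds more strongly to a phenyl ring carrying an amine or a carboxylic acid, and whether a longer chain in place of the 2-hydroxyethoxy group would shift the values at all.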